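Permeability notes: switching the hydroxy acid substituent on compound 2

The source may hold more compounds than are shown below. What is called first, only, known or untested is meant among the compounds shown, and "the series" means these compounds.

Compound 1 is `COC(C)(C)[C@@H](O)C(=O)N1N=CC[C@H]1C(=O)NCc1cc(Cl)ccc1-n1cnnn1` and compound 2 is `CC1(C[C@@H](O)C(=O)N2C[C@H]3C[C@H]3[C@H]2C(=O)NCc2cc(Cl)ccc2-n2cnnn2)CC1`. In an ADME assay on Caco-2 cells (Homo sapiens) for permeability, read by LC-MS, in the apical to basolateral direction, with a stated time of 60 min, at pH 6.5 (on this read-out lower numbers stand for lower permeability and higher numbers for higher permeability), compound 1 gives 1.7 10^-6 cm/s, and in this assay compound 2 gives 2.2 10^-6 cm/s. Compound 2 holds the higher of the two numbers recorded so far, but its gap to compound 1 lies within the scatter of repeated runs, so the two compounds are read as indistinguishable on this read-out, both at the low end of what this assay reports.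

The next compound, compound 3, is `O=C(NCc1cc(Cl)ccc1-n1cnnn1)[C@@H]1[C@@H]2C[C@@H]2CN1C(=O)[C@H](O)c1ccccc1F`. Its relation to compound 2 is 2-fluorophenyl in place of (1-methylcyclopropyl)methyl on a saturated chain carbon bound to a carbonyl carbon and an oxygen on a saturated carbon. For the measured compounds named here, no measured pair shows a change of this kind, so there is no step from measured compounds to lean on; only the structures and the two values are available.

With both measured compounds lying close together in this assay, a change of this sort is expected to move the number little, if at all: the step of a 1.1-fold higher number from compound 2 to compound 3 (0.06 log units; within the scatter) is expected to stay within the scatter, with no clear direction. Compound 3 is accordingly estimated at 2.5 10^-6 cm/s, in the range 1.2 10^-6 cm/s to 5 10^-6 cm/s.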

Compound 3, apparent permeability: 2.3 10^-6 cm/s
Beside the measured number, compound 3's estimate is 1.1-fold (0.04 log units) above it; measured number inside the range.
By their numbers in this assay, from the lowest: compounds 1, 2 and 3 (each within the scatter of the next).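

For the compounds shown here, at the position on a saturated chain carbon bound to a carbonyl carbon and an oxygen on a saturated carbon, 2-fluorophenyl in place of (1-methylcyclopropyl)methyl gives a 1.0-fold higher number from compound 2 to compound 3 (0.02 log units; within the scatter) in this assay, the first step in which only one place differs. On this read-out, compound 2 and compound 3 cannot be told apart, even though a six-membered aromatic ring of carbon only stands in compound 3 where compound 2 has a three-membered non-aromatic ring of carbon only, and neither group carries a hydrogen-bond donor, a hydrogen-bond acceptor or a net charge. No supporting measurement is available to account for this outcome.

Open, going by these compounds, is whether an amine or a carboxylic acid at this position, or a longer chain, would give a step beyond the scatter in this assay. Also open, on these data alone, is whether unsubstituted phenyl would read the same as 2-fluorophenyl here, and whether the same exchange on the core of compound 1 would give a comparable step.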